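Pyrazoline acyl series: cytotoxicity in prostate carcinoma cells

A few compounds are considered here, and "the series" means these few. Any claim that something is new, unique, unknown or untested is made for them only; others in the source may bear on it.

Measured so far:
- compound 1, `CC1=NN(C(=O)/C=C/c2ccccc2)C(c2ccccc2O)C1`: 42000 nM
- compound 2, `O=C(c1ccccc1)N1N=C(c2cc3ccccc3oc2=O)CC1c1ccccc1`: 5870 nM

Two compounds have numbers in a functional assay on PC-3 cells (Homo sapiens) for cytotoxicity, read by MTT assay, with a stated time of 48 h; on this read-out higher numbers stand for weaker inhibition and lower numbers for stronger inhibition. Compound 1 gives 42000 nM in this assay, and compound 2 gives 5870 nM. Compound 2 therefore holds the lower of the two numbers, and the gap between the two lies beyond the scatter of repeated measurements; with only these two points nothing can be said about which part of the structures carries the difference.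

The next step goes from compound 2 to compound 3, `CC1CCCN(CC(=O)N2N=C(c3cc4ccccc4oc3=O)CC2c2ccccc2)C1`. The change is confined to the acyl group on the ring nitrogen: (3-methylpiperidin-1-yl)methyl in place of phenyl on a carbonyl carbon. Going by the values given here, no pair of measured compounds shows this kind of exchange, so there is no measured step to lean on. The expectation is that the step from compound 2 to compound 3 in this assay stays small, at most slightly weaker, and possibly within the scatter, namely a 1.4-fold higher number from compound 2 to compound 3 (0.13 log units; within the scatter).

Compound 3 is estimated to give about 8000 nM in this assay, with a plausible range from 2000 nM to 30000 nM.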

Compound 3, half-maximal inhibitory concentration: 28300 nM
Estimate against measurement, compound 3: 3.5-fold (0.55 log units) below; the range from low to high includes it.
By their numbers in this assay, from the lowest: compound 2; then compounds 3 and 1 (each within the scatter of the next).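

In this assay, the acyl group on the ring nitrogen now has its first measured exchange: (3-methylpiperidin-1-yl)methyl in place of phenyl on a carbonyl carbon gives a 4.8-fold higher number from compound 2 to compound 3 (0.68 log units; beyond the scatter). This position is therefore not indifferent to the group on the carbonyl carbon, and of the two groups tested here, phenyl goes with the stronger inhibition, although the step is modest. No measurement at hand bears on what lies behind this step.

The single exchange replaces an aromatic ring of carbon only with a non-aromatic ring holding one nitrogen, and adds a methyl group and a carbon link at the same time, so the compounds shown leave open which of these parts carries the step. A benzyl group, an unsubstituted piperidin-1-ylmethyl group or a morpholin-4-ylmethyl group on the same carbonyl carbon would help to separate these parts, and would show whether the weaker inhibition holds across other amines.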